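A few compounds are considered here, and "the series" means these few. Any claim that something is new, unique, unknown or untested is made for them only; others in the source may bear on it.

The measured compounds:

compound 1, `C=C1C(=O)[C@]23C[C@@]1(O)CC[C@H]2c1ccc(OS(=O)(=O)c2ccc(C)cc2)c(C)c1[C@@H]3Cn1cc(-c2ccc(Cl)cc2)nn1`, gives 2390 nM in a functional assay on SW480 cells (Homo sapiens) for cytotoxicity, read by MTT assay, with a stated time of 4 days; on this read-out higher numbers stand for weaker inhibition and lower numbers for stronger inhibition
compound 2, `C=C1C(=O)[C@]23C[C@@]1(O)CC[C@H]2c1ccc(OS(=O)(=O)c2ccc(C)cc2)c(C)c1[C@@H]3Cn1cc(-c2ccc(C)cc2)nn1`, gives 1460 nM in this assay
compound 3, `C=C1C[C@]23C[C@@]1(O)CC[C@H]2c1cc(Br)c(O)c(C)c1[C@@H]3Cn1cc(-c2ccc(C)cc2)nn1`, gives only a limit, > 20000 nM, in this assay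

Compound 2 and compound 1 share one core and differ in a single place, (chloro in place of methyl on an aromatic carbon). On this change the read-out moved by a 1.6-fold higher number from compound 2 to compound 1 (0.21 log units; within the scatter), so the two aryl groups behave alike within the usual scatter of the measurement. Compound 3 carries a different core; the difference between the two cores is not broken down here. Compound 3 sits at the limit of > 20000 nM in this assay, at which 1 of the 3 values shown sits, so for it the assay gives a limit and not a number.

Compound 4, `C=C1C[C@]23C[C@@]1(O)CC[C@H]2c1cc(Br)c(O)c(C)c1[C@@H]3Cn1cc(-c2ccc(Cl)cc2)nn1`, has not yet been measured in this assay. It differs from compound 3 by chloro in place of methyl on an aromatic carbon, the same change as that from compound 2 to compound 1, made at the same place. Because the measured step was a 1.6-fold higher number from compound 2 to compound 1 (0.21 log units; within the scatter), the same change on the core of compound 3 is expected to move the read-out little. For compound 4 the expected step is a step that the limit leaves unreadable from compound 3 to compound 4. Compound 4 is therefore expected to lie at or near the limit, with an estimated value of 30000 nM in this assay, most likely between 12000 nM and 80000 nM. Whether a number rather than a limit is returned for compound 4 remains to be seen.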

Compound 4, half-maximal inhibitory concentration: 18000 nM
Compound 4: the middle estimate sits 1.7-fold (0.22 log units) above what was measured; low and high end bracket the measured number.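

On the second core in this assay, going from 4-methylphenyl to 4-chlorophenyl gives an at least 1.1-fold lower number from compound 3 to compound 4 (0.04 log units; that floor lies within the scatter), which is a floor and not a full step. Set beside the same change on the first core, the result reads: the same change on two cores in this assay, a 1.6-fold higher number (0.21 log units; within the scatter) from compound 2 to compound 1 and an at least 1.1-fold lower number (0.04 log units; that floor lies within the scatter) from compound 3 to compound 4; the limit leaves it open whether they differ The two cores therefore give no sign that the change acts differently from one to the other, but they do not show that it acts alike either, and the open end of the second step rests on compound 3, whose value is a limit: the limit of > 20000 nM in this assay, at which 1 of the 4 values shown sits.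

The compounds shown leave open how an amine or a carboxylic acid in place of the chloro would read in this assay on either core. They also leave open what each single difference between the core of compound 1 and the core of compound 3 contributes on its own, since no pair shown here separates those differences.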